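A larger amine on a compound with only a limit

The compounds below may be only part of what the source reports. "The series", "measured", "known", "first", "only" and "open" are said of these compounds alone.

compound 1 `Cc1c(Cc2c(F)cccc2F)nc(N(C)C)[nH]c1=O`: > 89000 nM
compound 2 `Cc1c(C(C)c2c(F)cccc2F)nc(N(C)C)[nH]c1=O`: > 17000 nM
compound 3 `CCc1c(C(C)c2c(F)cccc2F)nc(N(C)C)[nH]c1=O`: > 81000 nM

All three entries come from an ADME assay on MT4 cells (Homo sapiens) for cytotoxicity, read by MTT assay, with a stated time of 4 days (on this read-out lower numbers stand for higher toxicity in this test and higher numbers for lower toxicity in this test), and each is a limit of the assay rather than a number. Compound 2 therefore has no exact place on the scale.

Compound 4 `Cc1c(C(C)c2c(F)cccc2F)nc(N2CCCC(C)C2)[nH]c1=O` differs from compound 2 in one place: 3-methylpiperidin-1-yl in place of dimethylamino on an aromatic carbon, between two ring nitrogen atoms (3-methylpiperidin-1-yl in place of dimethylamino on an aromatic carbon).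

Two measured steps involve compound 2, and both change a saturated chain carbon while dimethylamino stays in place. One is a step that the two limits leave unreadable from compound 1 to compound 2, and the other is a step that the two limits leave unreadable from compound 2 to compound 3. Neither has a readable size, and neither tests this amine swap, so they give only weak guidance.

The nearest reference is compound 2, with its limit of > 17000 nM. On that basis, no step beyond the scatter is expected in this assay, and no direction can be predicted with confidence.

The estimated step is a step that the limit leaves unreadable from compound 2 to compound 4.

For compound 4, the expected value is about 30000 nM, with an estimated range from 9000 nM to 100000 nM.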

Compound 4, half-maximal cytotoxic concentration: > 72000 nM
Compound 4 gave a limit, no number (the forecaster's own chance of this, stated with the estimate: 55%); middle value at least 2.4-fold (0.38 log units) away from the limit.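

Compound 2 and compound 4 each carry only a limit, not a number, and no step can be read from one to the other. The compounds shown leave open at what concentration any of them harms the cells, and whether 3-methylpiperidin-1-yl in place of dimethylamino changes that concentration at all.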